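Oxime ether series: cytotoxicity notes on four compounds

The source may report more compounds than this note shows. Statements on the series, on what has been measured and on what is new or still open speak of the compounds shown alone.

Compound 1 `Cc1ccc(CO/N=C2/C(c3c[nH]c4ccccc34)=Nc3ccccc32)cc1`: in an ADME assay on HUVEC cells (Homo sapiens) for cytotoxicity, read by MTT assay, with a stated time of 2 days (on this read-out lower numbers stand for stronger inhibition and higher numbers for weaker inhibition), compound 1 gives > 100000 nM, which is a limit of the assay and not a number.
Compound 2 `Cc1ccc(CO/N=C2/C(c3c[nH]c4ccc(Br)cc34)=Nc3ccc(Br)cc32)cc1`: in this assay compound 2 gives > 100000 nM, again a limit of the assay.
Compound 3 `FC(F)(F)c1ccc(CO/N=C2/C(c3c[nH]c4ccccc34)=Nc3ccccc32)cc1`: in this assay compound 3 gives > 100000 nM, also a limit of the assay.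

Compound 1 and compound 3 differ in one place: trifluoromethyl in place of methyl on an aromatic carbon. Because (the limit of > 100000 nM in this assay, at which 3 of the 3 values shown sit), the step that the two limits leave unreadable from compound 1 to compound 3 cannot be read in size; both ends sit at the limit and nothing more can be said of it. The difference between the core of compound 1 and the core of compound 2 is not broken down here.

Compound 4 `FC(F)(F)c1ccc(CO/N=C2/C(c3c[nH]c4ccc(Br)cc34)=Nc3ccc(Br)cc32)cc1` has not yet been measured in this assay. Compound 4 stands to compound 2 as compound 3 stands to compound 1, and the change is the same: trifluoromethyl in place of methyl on an aromatic carbon. The surroundings of the place are the same in both pairs.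

With compound 1, compound 2 and compound 3 all at the limit, no value among them gives a number to build on. The expectation for compound 4 therefore rests only on compound 2, whose value is > 100000 nM, and on the unreadable step that the two limits leave unreadable from compound 1 to compound 3. The step from compound 2 to compound 4 is expected to be a number no higher from compound 2 to compound 4 (the limit leaves the size open), that is, no readable change. Compound 4 is expected to give about 100000 nM in this assay, most likely reported again as a limit, with a range estimated between 50000 nM and 300000 nM.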

Compound 4, half-maximal inhibitory concentration: > 100000 nM
Compound 4: only a limit was reported; the forecaster's own chance of this, stated with the estimate: 90%; the middle value lies on the limit itself.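

No new step can be read from compound 2 to compound 4, or anywhere else among the four compounds, because every value in this assay sits at the limit: the limit of > 100000 nM in this assay, at which 4 of the 4 values shown sit.

The compounds shown leave open whether trifluoromethyl in place of methyl changes the value in this assay at all, and at what concentration, if any, these compounds would reach half-maximal inhibition.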